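Swapping 4-chlorophenyl for 2-methylphenyl on the shared core

The source may hold more compounds than are shown below. What is called first, only, known or untested is meant among the compounds shown, and "the series" means these compounds.

Compound 1 `O=C1C=C(N2CCN(c3ccccc3Cl)CC2)C(=O)c2ccccc21`: 41800 nM
Compound 2 `O=C1C=C(N2CCC(c3ccccc3)CC2)C(=O)c2c(O)cccc21`: 11100 nM
Compound 3 `O=C1C=C(N2CCC(c3ccc(Cl)cc3)CC2)C(=O)c2c(O)cccc21`: > 50000 nM (a limit, not a number)

These results come from a functional assay on SGC-7901 cells (Homo sapiens) for antiproliferative activity, read by MTT assay, with a stated time of 72 h; on this read-out lower numbers stand for stronger inhibition and higher numbers for weaker inhibition. Compound 3 gives > 50000 nM, which is only a limit of the measurement. That makes it (the limit of > 50000 nM in this assay, at which 1 of the 3 values shown sits).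

Compound 4 `Cc1ccccc1C1CCN(C2=CC(=O)c3cccc(O)c3C2=O)CC1` is reached from compound 3 by one change, 2-methylphenyl in place of 4-chlorophenyl on a saturated ring carbon. Among the compounds with values here, one measured step bears on this, an at least 4.5-fold higher number from compound 2 to compound 3 (0.65 log units; beyond the scatter), where chloro took the place of hydrogen on an aromatic carbon. Compound 4 no longer carries that chloro, so the step may be partly undone. Within the data shown here, none of the measured compounds carries the methyl group.

A lower number is therefore expected in this assay, moving toward compound 2 at 11100 nM. The expected change is an at least 2.7-fold lower number from compound 3 to compound 4 (0.44 log units; beyond the scatter). For compound 4 the estimated value is 18000 nM. The expected range for compound 4 runs from 6000 nM to 50000 nM.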

Compound 4, half-maximal inhibitory concentration: 3900 nM
Compound 4: the middle estimate sits 4.6-fold (0.66 log units) above what was measured, and the stated range ends above it.
By their numbers in this assay, from the lowest: compound 4; then compound 2; then compound 1. At a limit, above all of these: compound 3.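

In this assay, the aromatic group on the saturated ring carbon proves able to move activity a long way: putting 2-methylphenyl in place of 4-chlorophenyl gives an at least 12-fold lower number from compound 3 to compound 4 (1.10 log units; beyond the scatter). From the compounds shown here alone, compound 3 stands at a limit, not a number, so the true size of that step stays unknown: the limit of > 50000 nM in this assay, at which 1 of the 4 values shown sits. Substitution on this aromatic ring can also push the number either way, since methyl in place of hydrogen gives a 2.8-fold lower number from compound 2 to compound 4 (0.45 log units; beyond the scatter), whereas chloro in place of hydrogen gave an at least 4.5-fold higher number from compound 2 to compound 3 (0.65 log units; beyond the scatter).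

The compounds shown do not separate the effect of the group from that of its place on the aromatic ring, and a 4-methylphenyl group would help to tell the two apart. Going by these compounds, whether an ethyl or methoxy group would lower the number further also remains open.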